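Heteroaryl swap on the thioether of a spiroketal sugar

The source may hold more compounds than are shown below. What is called first, only, known or untested is meant among the compounds shown, and "the series" means these compounds.

Measured compounds:
- Compound 1 `Nc1nnc(SC[C@H]2O[C@@H](OCc3noc(-c4ccc(Cl)cc4)n3)[C@@H]3OC4(CCCC4)O[C@@H]32)s1` — 18000 nM
- Compound 2 `Nc1nnc(SC[C@H]2O[C@@H](OCc3noc(-c4ccc([N+](=O)[O-])cc4)n3)[C@@H]3OC4(CCCC4)O[C@@H]32)s1` — 19000 nM
- Compound 3 `CC(=O)OC[C@H]1O[C@@H](OCc2noc(-c3ccc([N+](=O)[O-])cc3)n2)[C@@H]2OC3(CCCC3)O[C@@H]21` — 52000 nM

In a functional assay on T47D cells (Homo sapiens) for antiproliferative activity, read by sulforhodamine B assay, with a stated time of 48 h (on this read-out lower numbers stand for stronger inhibition of growth and higher numbers for weaker inhibition of growth), compound 1 gives the lowest of the three numbers. Compound 2 sits close by it, as a 1.1-fold higher number from compound 1 to compound 2 (0.02 log units; within the scatter) shows, so nothing separates the two. Compound 3 stands furthest off, and the step of a 2.7-fold higher number from compound 2 to compound 3 (0.44 log units; beyond the scatter) is the only one here that goes beyond the scatter.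

Compound 4 `Clc1ccc(-c2nc(CO[C@@H]3O[C@H](CSc4ncn[nH]4)[C@H]4OC5(CCCC5)O[C@@H]34)no2)cc1` has not been measured. It differs from compound 1 in one place: 1H-1,2,4-triazol-5-yl in place of 5-amino-1,3,4-thiadiazol-2-yl on a sulfur. Among the compounds with values here, no measured pair exchanges one heteroaryl for another on that sulfur. The nearest guide is a 2.7-fold higher number from compound 2 to compound 3 (0.44 log units; beyond the scatter), where the whole (5-amino-1,3,4-thiadiazol-2-yl)sulfanyl group was replaced by acetoxy and the number rose modestly. Compound 4 keeps the sulfanyl link and a five-membered aromatic ring with 3 hetero atoms, so the expected step of a 1.4-fold higher number from compound 1 to compound 4 (0.14 log units; within the scatter) is small, likely within the scatter or a little toward weaker inhibition. Compound 4 is therefore estimated at 25000 nM, with a range of 10000 nM to 70000 nM.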

Compound 4, concentration for 50% growth inhibition: 10000 nM
Compound 4: the middle estimate sits 2.5-fold (0.40 log units) above what was measured; the range from low to high includes it.
By their numbers in this assay, from the lowest: compounds 4, 1 and 2 (each within the scatter of the next); then compound 3.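

In this assay, within the data shown here, this is the first exchange of one heteroaryl for another on the sulfur, and a 1.8-fold lower number from compound 1 to compound 4 (0.26 log units; within the scatter) shows that the (5-amino-1,3,4-thiadiazol-2-yl)sulfanyl group can give way to (1H-1,2,4-triazol-5-yl)sulfanyl without a change beyond the scatter. Among these compounds, the entering ring has no ring sulfur or amino group, and it has fewer heavy atoms and hydrogen-bond acceptors, yet compound 4 cannot be separated from compound 1, whereas the only earlier change at this position, to acetoxy, gave a 2.7-fold higher number from compound 2 to compound 3 (0.44 log units; beyond the scatter). Nothing available explains why the number holds across this exchange.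

The compounds shown leave open how a phenyl ring or a plain methyl on that sulfur would read. They also leave open whether an amino group on the 1H-1,2,4-triazol-5-yl ring would shift the number.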